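This account rests on a few compounds, and the source may have more. Where it says the series, first, only, none or still open, it means among the compounds named here.

Compound 1 `CCN(CC)CCNC(=O)C1CC(C(CC)(CC)c2ccc(C#CC(C)(O)CC)c(C)c2)=CN1CC`: 2780 nM
Compound 2 `CCN(CC)CCNC(=O)C1CC=C(C(CC)(CC)c2ccc(C#CC(C)(C)O)c(C)c2)N1CC`: 1490 nM

In a functional assay on MCF7 cells (Homo sapiens) for antiproliferative activity, read by MTT assay, with a stated time of 24 h (on this read-out higher numbers stand for weaker inhibition and lower numbers for stronger inhibition), compound 1 gives 2780 nM and compound 2 gives 1490 nM. These two values lie within the usual scatter of each other, so neither compound can be ranked above the other. Compound 3 `C#Cc1ccc(C(CC)(CC)C2=CN(CC)C(C(=O)NCCN(CC)CC)C2)cc1C` is not yet measured. It has hydrogen in place of 1-hydroxy-1-methylpropyl on a triple-bonded carbon (the change from compound 1: hydrogen in place of 1-hydroxy-1-methylpropyl on a triple-bonded carbon). Among the measured compounds shown here, no measured pair shows this change, so only a modest, uncertain step towards weaker inhibition is expected (a 1.4-fold higher number from compound 1 to compound 3 (0.16 log units; within the scatter)). For compound 3 the estimated value is 4000 nM (expected range 1200 nM to 13000 nM).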

Compound 3, half-maximal inhibitory concentration: > 50000 nM
Compound 3 gave a limit, no number; the forecaster's own chance of this, stated with the estimate: 10%; at least 12-fold (1.09 log units) between middle value and limit.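

In this assay compound 3 gives > 50000 nM, which is a limit of the assay and not a number. Among the compounds shown here, putting hydrogen in place of 1-hydroxy-1-methylpropyl on the triple-bonded carbon gives an at least 17-fold higher number from compound 1 to compound 3 (1.25 log units; beyond the scatter), so what this position carries matters greatly for this read-out, which the earlier compounds could not show. The full size of the step stays unknown: the limit of > 50000 nM in this assay, at which 1 of the 3 values shown sits.

The compounds shown do not separate the part played by the hydroxyl from that of the carbon chain in the group that leaves. They also leave open how an amine or a simple ethyl group would read at this position.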